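From 4-Methoxyphenyl to 2-Methoxyphenyl: An Expected Flat Step

This account rests on a few compounds, and the source may have more. Where it says the series, first, only, none or still open, it means among the compounds named here.

Of the compounds shown here, three have been measured so far in an ADME assay on CCRF-CEM cells (Homo sapiens) for antiproliferative activity, with a stated time of 48 h; a higher number here means a weaker inhibitor, a lower number a stronger inhibitor. Compound 1 `C=C(Br)C(=O)Nc1ccc(/C=C/C(=O)c2ccc(F)cc2)cc1` gives 1100 nM, compound 2 `C=C(Br)C(=O)Nc1ccc(/C=C/C(=O)c2ccc(Br)cc2)cc1` gives 990 nM and compound 3 `C=C(Br)C(=O)Nc1ccc(C(=O)/C=C/c2ccc(OC)cc2)cc1` gives 1100 nM. These numbers lie within the usual scatter of repeated measurements, so compound 3 stands level with the other two.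

Compound 4 `C=C(Br)C(=O)Nc1ccc(C(=O)/C=C/c2ccccc2OC)cc1` has the same atoms as compound 3, joined differently: 2-methoxyphenyl sits in place of 4-methoxyphenyl on a double-bonded chain carbon bound to a double-bonded chain carbon (2-methoxyphenyl in place of 4-methoxyphenyl on a double-bonded chain carbon bound to a double-bonded chain carbon).

Among the measured compounds shown here, only one measured step is available as a guide, and it is a different kind of change: bromo in place of fluoro on an aromatic carbon gave a 1.1-fold lower number from compound 1 to compound 2 (0.05 log units; within the scatter). For the measured compounds named here, no measured step shows what moving the methoxy group does, so this guide is weak. Since that one step stayed within the scatter, no shift beyond the scatter is expected here, in either direction.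

The estimated step is a 1.1-fold lower number from compound 3 to compound 4 (0.04 log units; within the scatter). Compound 4 is expected at 1000 nM, with an estimated range of 450 nM to 2300 nM.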

Compound 4, half-maximal inhibitory concentration: 580 nM
Compound 4: middle estimate off by 1.7-fold (0.24 log units), on the high side, and the stated range covers the measured number.
By their numbers in this assay, from the lowest: compounds 4, 2, 1 and 3 (each within the scatter of the next).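

In this assay, among the compounds shown here, placing 2-methoxyphenyl where 4-methoxyphenyl stood, on a double-bonded chain carbon bound to a double-bonded chain carbon, gives a 1.9-fold lower number from compound 3 to compound 4 (0.28 log units; within the scatter) and so provides the first measured look at moving the methoxy group around this ring. These two placements of the methoxy group cannot be told apart in this read-out, so neither can be called the better one. No measurement on hand bears on this result.

The compounds shown leave open whether a different group at this place, such as an amine, a carboxylic acid or a longer chain, would produce a step beyond the scatter. From the compounds shown here alone, it also remains open whether moving a group around the halogen-bearing ring of compound 1 or compound 2 would stay just as flat.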